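A few compounds are considered here, and "the series" means these few. Any claim that something is new, unique, unknown or untested is made for them only; others in the source may bear on it.

Compound 1 `CCOC(=O)[C@H](CCC(=O)O)NC(=O)c1ccc(CNc2nc3cc(N)cc(N)c3nc2-c2ccccc2)cc1` gives < 100000 nM in a functional assay on SK-MEL-5 cells (Homo sapiens) for inhibition, read by sulforhodamine B assay, with a stated time of 48 h (on this read-out lower numbers stand for stronger inhibition of growth and higher numbers for weaker inhibition of growth), which is a limit of the assay and not a number.
Compound 2 `CCOC(=O)[C@H](CCC(=O)O)NC(=O)c1ccc(Oc2nc3cc(N)cc(N)c3nc2-c2ccccc2)cc1` gives 53700 nM in this assay.
Compound 3 `COc1ccc(Sc2nc3cc(N)cc(N)c3nc2-c2ccccc2)cc1` gives < 100000 nM in this assay, again a limit of the assay rather than a measured number.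

Compound 3 therefore stands at the edge of what this assay can report, and it shares that place with another of the three values shown (the limit of < 100000 nM in this assay, at which 2 of the 3 values shown sit). Compound 4 `Nc1cc(N)c2nc(-c3ccccc3)c(Sc3ccc(F)cc3)nc2c1` differs from compound 3 by fluoro in place of methoxy on an aromatic carbon. Among the compounds with values here, no measured pair in this set isolates such a change, so there is no step to lean on. The step that the limit leaves unreadable from compound 3 to compound 4 is expected to stay within the usual scatter, with no clear direction. Compound 4 is thus estimated at 80000 nM, within a range from 30000 nM to 200000 nM.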

Compound 4, concentration for total growth inhibition: 33100 nM
Beside the measured number, compound 4's estimate is 2.4-fold (0.38 log units) above it; low and high end bracket the measured number.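

No step can be read from compound 3 to compound 4, because compound 3 gives only a limit of the assay: the limit of < 100000 nM in this assay, at which 2 of the 4 values shown sit.

The compounds shown leave open whether fluoro in place of methoxy on an aromatic carbon changes the result in this assay at all.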